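The source may report more compounds than this note shows. Statements on the series, on what has been measured and on what is new or still open speak of the compounds shown alone.

In a functional assay on NCI-H460 cells (Homo sapiens) for inhibition, with a stated time of 72 h (a higher number here means a weaker inhibitor, a lower number a stronger inhibitor), compound 2 `COc1ccc(S(=O)(=O)N2CCc3cccc(-c4ccc([N+](=O)[O-])cc4)c32)cc1` gives 53.1 nM. Compound 1 `COc1ccc(S(=O)(=O)N2CCc3cccc(-c4ccco4)c32)cc1` gives 94.5 nM, which cannot be told apart from compound 2: the step is a 1.8-fold lower number from compound 1 to compound 2 (0.25 log units; within the scatter). Compound 3 `COc1ccc(S(=O)(=O)N2CCc3cccc(-c4cc(OC)c(OC)c(OC)c4)c32)cc1` stands far higher, at 6340 nM.

Compound 4 `COc1ccc(S(=O)(=O)N2CCc3cccc(-c4cccc(F)c4)c32)cc1` carries 3-fluorophenyl in place of 4-nitrophenyl on an aromatic carbon. Among the measured compounds shown here, the only measured step at this place is the furan-2-yl to 4-nitrophenyl exchange, a 1.8-fold lower number from compound 1 to compound 2 (0.25 log units; within the scatter), so one change of ring there left this assay unmoved. For the measured compounds named here, compound 3, at 6340 nM, warns that another aryl group at the same place can give a much higher number, and no measured compound yet carries a fluorine. On this basis, no step beyond the scatter is expected, with some lean towards a higher number. The expected step is a 1.9-fold higher number from compound 2 to compound 4 (0.27 log units; within the scatter). For compound 4 the estimate is 100 nM, with an expected range of 30 nM to 400 nM.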

Compound 4, half-maximal inhibitory concentration: 167 nM
The estimate for compound 4 lay 1.7-fold (0.22 log units) below the measured number; the range from low to high includes it.
By their numbers in this assay, from the lowest: compounds 2, 1 and 4 (each within the scatter of the next, the first and the last beyond it); then compound 3.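

At this aromatic carbon, a ring exchange now gives a modest step beyond the scatter in this assay: a 3.1-fold higher number from compound 2 to compound 4 (0.50 log units; beyond the scatter). The same 3-fluorophenyl group set against furan-2-yl gives a 1.8-fold higher number from compound 1 to compound 4 (0.25 log units; within the scatter), so compound 1 cannot be told apart from either compound 2 or compound 4, and only the latter two are separated; compound 3, at 6340 nM, still stands far from this group. No measured evidence on the compounds bears on what lies behind these numbers.

Open, going by these compounds, is how much of the step from 4-nitrophenyl to 3-fluorophenyl rests on the nitro group and how much on the fluorine, which a plain phenyl at this carbon would help separate. Also open, on these data alone, is whether an amine or a carboxylic acid on this ring would stay near compound 2 or move towards compound 3.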